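Propargyl on the amine of a safinamide-like carboxamide

The source may hold more compounds than are shown below. What is called first, only, known or untested is meant among the compounds shown, and "the series" means these compounds.

Compound 1 `Cc1cc(OCc2cccc(F)c2)ccc1CN[C@@H](C)C(N)=O` is measured in an assay on Sf9 cells for inhibition of Amine oxidase [flavin-containing] A (Homo sapiens), with stated times of 15 min and 60 min (on this read-out lower numbers stand for stronger inhibition and higher numbers for weaker inhibition), where compound 1 gives only a limit of > 10000 nM. Compound 2 `Cc1cc(OCc2cccc(F)c2)ccc1CN1CC[C@H]1C(N)=O` gives 8650 nM in this assay, a step of an at least 1.1-fold lower number from compound 1 to compound 2 (0.06 log units; that floor lies within the scatter). Compound 3 `C[C@H](NCc1ccc(OCc2cccc(F)c2)cc1F)C(N)=O` gives only a limit of > 10000 nM in this assay, so the step that the two limits leave unreadable from compound 1 to compound 3. Two of the three values sit at the limit of > 10000 nM in this assay, at which 2 of the 3 values shown sit. Compound 4 `C#CCN(Cc1ccc(OCc2cccc(F)c2)cc1C)[C@@H](C)C(N)=O` differs from compound 1 in one place: propargyl in place of hydrogen on an amine nitrogen. Neither measured step touches the amine nitrogen, so neither bears on this change, and the limit for compound 1 leaves its starting point unfixed. Compound 4 is expected to give about 3000 nM in this assay, between 800 nM and 12000 nM, an expected step of an at least 3.3-fold lower number from compound 1 to compound 4 (0.52 log units; beyond the scatter).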

Compound 4, half-maximal inhibitory concentration: 6400 nM
Estimate against measurement, compound 4: 2.1-fold (0.33 log units) below; the measured number falls inside the stated range.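

With propargyl in place of hydrogen on the amine nitrogen, this position gives a step in this assay: an at least 1.5-fold lower number from compound 1 to compound 4 (0.19 log units; that floor lies within the scatter). Compound 1 gives only a limit, > 10000 nM, so this step is a floor and the true size of the change remains unfixed. Such limits are common among the compounds shown: the limit of > 10000 nM in this assay, at which 2 of the 4 values shown sit.

Going by these compounds, whether a methyl, an allyl or a propyl group on this amine nitrogen would give a number like that of compound 4 remains open. The compounds shown therefore do not tell whether the triple bond matters.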